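The compounds below may be only part of what the source reports. "The series", "measured", "known", "first", "only" and "open" are said of these compounds alone.

In a functional assay on cells (Rhabdomyosarcoma cell, Homo sapiens) for cytotoxicity (a higher number here means a weaker inhibitor, a lower number a stronger inhibitor), compound 3 `c1ccc(C(c2ccco2)N2CCN(c3ncnc4c3cnn4-c3ccccc3)CC2)cc1` gives only a limit of the assay, > 25000 nM. Compound 1 `Clc1ccc(C(c2ccccc2)N2CCN(c3ncnc4c3cnn4-c3ccccc3)CC2)cc1` likewise gives only a limit, > 25000 nM. Compound 2 `Cc1ccsc1C(c1ccccc1)N1CCN(c2ncnc3c2cnn3-c2ccccc2)CC1` also gives only a limit, > 25000 nM. The steps a step that the two limits leave unreadable from compound 1 to compound 2, a step that the two limits leave unreadable from compound 1 to compound 3 and a step that the two limits leave unreadable from compound 2 to compound 3 cannot be sized because of the limit of > 25000 nM in this assay, at which 3 of the 3 values shown sit. Compound 4 `c1ccc(C(c2ccncc2)N2CCN(c3ncnc4c3cnn4-c3ccccc3)CC2)cc1` has not yet been measured in this assay; its change from compound 3 is pyridin-4-yl in place of furan-2-yl on a saturated chain carbon bound to an amine nitrogen in a ring and an aromatic carbon. Among the measured compounds shown here, no measured step with a readable size bears on swapping one aromatic ring for another on that saturated chain carbon; all three values sit at the limit, so no direction beyond the scatter can be drawn. The expected step that the limit leaves unreadable from compound 3 to compound 4 is therefore taken as small. Compound 4 is estimated at 30000 nM, with a range from 12000 nM to 100000 nM, and most likely again only a limit.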

Compound 4, half-maximal inhibitory concentration: > 25000 nM
Compound 4 gave a limit, no number; the forecaster's own chance of this, stated with the estimate: 85%; the middle value does not contradict the limit.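

No step to compound 4 from compound 1, compound 2 or compound 3 can be read, because all four compounds share one limit: the limit of > 25000 nM in this assay, at which 4 of the 4 values shown sit.

From the compounds shown here alone, how the aromatic rings on that saturated chain carbon rank in this assay stays open.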